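Adding a Second Trifluoromethyl Group to a Sulfone Analogue

A few compounds are considered here, and "the series" means these few. Any claim that something is new, unique, unknown or untested is made for them only; others in the source may bear on it.

The compounds here were tested in a functional assay on DU-145 cells (Homo sapiens) for antiproliferative activity, read by propidium iodide staining, with a stated time of 96 h; on this read-out lower numbers stand for stronger inhibition and higher numbers for weaker inhibition. Compound 1 `CC(O)(COc1cccc(C(F)(F)F)c1)C(=O)Nc1cccc(S(F)(F)(F)(F)F)c1` gives 31700 nM. Compound 2 `CC(O)(COc1cc(C(F)(F)F)cc(C(F)(F)F)c1)C(=O)Nc1cccc(S(F)(F)(F)(F)F)c1` differs from compound 1 only by the change (trifluoromethyl in place of hydrogen on an aromatic carbon). In this assay compound 2 gives 9300 nM. That single change produced a 3.4-fold lower number from compound 1 to compound 2 (0.53 log units; beyond the scatter), a step that goes beyond the usual run-to-run scatter of this kind of measurement.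

Compound 3 `CC(O)(CS(=O)(=O)c1cccc(C(F)(F)F)c1)C(=O)Nc1ccc(S(F)(F)(F)(F)F)cc1` has a different core from compound 1; the difference between the two cores is not broken down here. In this assay compound 3 gives 31900 nM, and its value and that of compound 1 lie within the scatter of each other, so no order can be set between them.

Compound 4 `CC(O)(CS(=O)(=O)c1cc(C(F)(F)F)cc(C(F)(F)F)c1)C(=O)Nc1ccc(S(F)(F)(F)(F)F)cc1` has not yet been measured. Going by the values given here, it differs from compound 3 by the change (trifluoromethyl in place of hydrogen on an aromatic carbon), which is the same change as the one from compound 1 to compound 2: the same group enters, the same group leaves, and the surroundings of the place are described in the same words.

Among the compounds with values here, with only one earlier example of this change, and that example on a different core, the expectation for compound 4 rests on the single step of a 3.4-fold lower number from compound 1 to compound 2 (0.53 log units; beyond the scatter). From compound 3 a step of about a 2.9-fold lower number from compound 3 to compound 4 (0.46 log units; beyond the scatter) is therefore expected, with wider uncertainty than the measured step itself. Compound 4 is estimated to give 11000 nM in this assay, most likely between 4000 nM and 30000 nM.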

Compound 4, half-maximal inhibitory concentration: 24400 nM
Beside the measured number, compound 4's estimate is 2.2-fold (0.35 log units) below it; the range from low to high includes it.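

In this assay, the same change now gives a 1.3-fold lower number from compound 3 to compound 4 (0.12 log units; within the scatter), a step within the scatter, so on this core its effect cannot be told apart from no effect. Set beside the earlier case, the two steps cannot be said to differ: the same change on two cores in this assay, a 3.4-fold lower number (0.53 log units; beyond the scatter) from compound 1 to compound 2 and a 1.3-fold lower number (0.12 log units; within the scatter) from compound 3 to compound 4, 2.6-fold (0.42 log units) apart, within the scatter of two such steps. Going by these compounds alone, this shows that the data do not separate the two cores, but it does not show that the change carries over at the same size, since only one of the two steps lies beyond the scatter and a single pair on each core is too little to settle whether the change works equally well on both.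

The compounds shown leave open what other groups would do at the same place on either core, for example a chlorine atom, a nitrile or a methyl group, and whether a result on one core would then hold on the other. Within the data shown here, they also leave open which part of the difference between the two cores matters, since no compound here changes those parts one at a time.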